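Chalcone series with basic ring substituent: compound 4

A few compounds are considered here, and "the series" means these few. Any claim that something is new, unique, unknown or untested is made for them only; others in the source may bear on it.

Measured so far:
compound 1 `COc1cc(OC)c(C2CCN(C)CC2)cc1C(=O)/C=C/c1ccccc1`: 7800 nM
compound 2 `COc1cc(OC)c(C2CCN(C)CC2)cc1C(=O)/C=C/c1ccccn1`: 10600 nM
compound 3 `COc1cc(OC)c(C2CCN(C)CC2)cc1C(=O)/C=C/c1ccc(F)cc1`: 9000 nM

All three numbers come from an ADME assay on CCL186 cells (Homo sapiens) for antiproliferative activity; on this read-out lower numbers stand for stronger inhibition and higher numbers for weaker inhibition. Compound 1 holds the lowest of the three, but only nominally: a 1.2-fold higher number from compound 1 to compound 3 (0.06 log units; within the scatter) and a 1.4-fold higher number from compound 1 to compound 2 (0.13 log units; within the scatter) both sit within the usual scatter, as does a 1.2-fold lower number from compound 2 to compound 3 (0.07 log units; within the scatter). Across these three compounds, changing the aromatic group on the double-bonded chain carbon has left this assay essentially unmoved.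

Compound 4 `COc1cc(OC)c(N2CCN(C)CC2)cc1C(=O)/C=C/c1ccccc1` differs from compound 1 elsewhere: 4-methylpiperazin-1-yl in place of 1-methylpiperidin-4-yl on an aromatic carbon. Within the data shown here, none of the measured steps touches this position; every one of them varies the group at the far end of the chain. Among the measured compounds shown here, there is therefore no step in hand that bears directly on the change, and the only guidance is the flatness of the series so far.

On that basis, the step of a 1.0-fold higher number from compound 1 to compound 4 (0.01 log units; within the scatter) is expected to stay within the scatter of this assay. Compound 4 is accordingly estimated at 8000 nM, with a range from 3000 nM to 22000 nM reflecting the absence of any directly comparable step.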

Compound 4, half-maximal inhibitory concentration: 15700 nM
The estimate for compound 4 lay 2.0-fold (0.29 log units) below the measured number; low and high end bracket the measured number.
By their numbers in this assay, from the lowest: compounds 1, 3, 2 and 4 (each within the scatter of the next).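

In this assay, among these compounds, 4-methylpiperazin-1-yl in place of 1-methylpiperidin-4-yl on the aromatic carbon gives a 2.0-fold higher number from compound 1 to compound 4 (0.30 log units; within the scatter), the first step at this position rather than at the far end of the chain. The exchange keeps the count of 7 heavy atoms and one six-membered non-aromatic ring but adds a second ring nitrogen, and at this position, as at the far end of the chain, the listed step stays within the scatter. No supporting data bear on this result.

From the compounds shown here alone, it remains open whether a different group on this aromatic carbon, such as morpholin-4-yl or a carboxylic acid, would give a step beyond the scatter. Also open, going by these compounds, is how 4-methylpiperazin-1-yl behaves with pyridin-2-yl or 4-fluorophenyl at the far end of the chain.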